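Cytotoxicity notes on the shared-core series, towards compound 4

This account rests on a few compounds, and the source may have more. Where it says the series, first, only, none or still open, it means among the compounds named here.

Measured so far:
compound 1 `Cc1cc(-c2cccc(F)c2)c2ncc(CSCCc3ccccc3)n2c1` — 20 ug/mL
compound 2 `Cc1cc(-c2ccc(O)cc2)c2ncc(CSCCc3ccccc3)n2c1` — 20 ug/mL
compound 3 `Cc1cc(-c2cccs2)cn2c(CSCCc3ccccc3)cnc12` — 20 ug/mL

In an ADME assay on HEL cells (Homo sapiens) for cytotoxicity, with a stated time of 3 days (a higher number here means that more compound is tolerated, a lower number that less compound is tolerated), compound 1 gives 20 ug/mL. Compound 2 gives 20 ug/mL, and compound 3 gives 20 ug/mL. Within the data shown here, the one single-point step with both ends measured, 4-hydroxyphenyl in place of 3-fluorophenyl on an aromatic carbon, shows no change at the digits printed from compound 1 to compound 2 (within the scatter). Compound 3 stands level with compound 1 and with compound 2 at the digits shown; there is no counted step between compound 3 and either of them, and their values simply read alike.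

Compound 4 `Cc1cc(-c2ccc(C#N)cc2)cn2c(CSCCc3ccccc3)cnc12` has not yet been run in this assay. Against compound 3 the change is 4-cyanophenyl in place of thiophen-2-yl on an aromatic carbon. Among the measured compounds shown here, the only measured step that bears on it is the swap of the aryl group at the same position from compound 1 to compound 2, which stayed within the scatter, and the thiophen-2-yl of compound 3 sits at the same level as both. On that basis the step from compound 3 to compound 4 is expected to be no change at the digits printed from compound 3 to compound 4 (within the scatter), nothing beyond the scatter in either direction. Compound 4 is therefore estimated at 20 ug/mL, with a range of 10 ug/mL to 40 ug/mL.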

Compound 4, minimum cytotoxic concentration: >= 20 ug/mL
Compound 4: a limit, no number; the forecaster's own chance of this, stated with the estimate: 15%; the middle value lies on the limit itself.
By their numbers in this assay, from the lowest: compounds 1, 2 and 3 (each within the scatter of the next).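

In this assay, the exchange of thiophen-2-yl for 4-cyanophenyl on an aromatic carbon, meta to a methyl group and para to a fused ring, gives a number no lower from compound 3 to compound 4 (the limit leaves the size open). Among these compounds, this is the first readable step here from a five-membered aromatic ring with a hetero atom to a six-membered aromatic ring of carbon only, and the larger group with its nitrile leaves this assay with no lower number, whereas the earlier step, no change at the digits printed from compound 1 to compound 2 (within the scatter), joined two substituted phenyl groups. The result for compound 4 is a limit of the assay and not a number: the limit of >= 20 ug/mL in this assay, at which 1 of the 4 values shown sits.

As far as these compounds go, how far the number for compound 4 lies from that of compound 3 stays open, so the size of this step cannot be set beside any other. Also open, from the compounds shown here alone, is how this assay would read with a group of another kind at this position, such as an amine or a carboxylic acid on the aromatic ring, or an alkyl chain in place of the ring altogether.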